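Removing a fluorine from the para position of compound 1

A few compounds are considered here, and "the series" means these few. Any claim that something is new, unique, unknown or untested is made for them only; others in the source may bear on it.

Within the data shown here, compound 1, `Fc1ccc(-c2csc(N/N=C/c3ccc(Cl)cc3Cl)n2)cc1`, and compound 2, `Cc1ccc(-c2csc(N/N=C/c3cccs3)n2)cc1`, share a core and differ in more than one place, so no single step is computed between them. In a functional assay, read by spectrophotometry, with a stated time of 15 min, tested at 60 ug/mL (a higher number here means a stronger effect of the compound at the concentration tested, a lower number a weaker effect), compound 1 gives 92.4%, and compound 2 gives 84.4%; the two numbers lie within the usual scatter of each other, so nothing separates them.

Compound 3, `Clc1ccc(/C=N/Nc2nc(-c3ccccc3)cs2)c(Cl)c1`, differs from compound 1 in one place: hydrogen in place of fluoro on an aromatic carbon. Only a single fluorine leaves, and nothing is known from measured pairs about what such a removal does here. With both measured numbers already near the top of the scale, the step is expected to be small, and the estimate is a number 7.4 percentage points lower from compound 1 to compound 3 (within the scatter), a step downward or none beyond the scatter. In this assay compound 3 is expected to give 85%, with a range from 65% to 97%.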

Compound 3, a percentage reported as inhibition, at one concentration (the size of the read-out at that concentration, not a potency): 80.4%
Beside the measured number, compound 3's estimate is 4.6 percentage points above it; the range from low to high includes it.
By their numbers in this assay, from the lowest: compounds 3, 2 and 1 (each within the scatter of the next, the first and the last beyond it).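

In this assay, among these compounds, the change from 4-fluorophenyl to phenyl is the first step that can be read at a single place, and it comes to a number 12 percentage points lower from compound 1 to compound 3 (beyond the scatter). The fluorine in this position therefore counts for something: replacing this one atom with hydrogen shifts the read-out by a modest but real amount, although the read-out stays high. Nothing available explains why the number falls when this atom leaves.

Still open, as far as these compounds go, is what another group in the same place, such as a methoxy group, an amine or a carboxylic acid, would do to the number. Also open, from the compounds shown here alone, is whether removing the fluorine would cost the same amount if the rest of the molecule were different, as this is a single pair of compounds.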